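Turning the double bond of compound 1 from Z to E

The compounds below may be only part of what the source reports. "The series", "measured", "known", "first", "only" and "open" are said of these compounds alone.

Compound 1 `C/C(=C/c1cccc(C(=O)O)c1)c1ccc2c(c1)C(C)(C)CCC2(C)C` carries an acid on the ring at the end of a trisubstituted double bond. In a functional assay on HL-60 cells (Homo sapiens), with a stated time of 48 h (on this read-out lower numbers stand for an effect already at smaller amounts and higher numbers for an effect only at larger amounts of compound), compound 1 gives 80000 nM, the highest number among the two measured compounds. Within the data shown here, compound 2 `CC1(C)CCC(C)(C)c2cc(/C=C/c3ccc(N)cc3)ccc21`, which carries an amine instead of the acid and lacks the methyl on its double bond, gives 38000 nM in this assay; no step between these two has been worked out, so their two values are only set side by side here, and they show compound 2 with the lower number.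

Compound 3 `C/C(=C\c1cccc(C(=O)O)c1)c1ccc2c(c1)C(C)(C)CCC2(C)C` is the partner of compound 1: the two compounds have the same atoms and bonds and differ only in configuration as drawn: 1 of 1 stereo elements differ; a double bond is drawn Z in compound 1 and E in compound 3. Among the measured compounds shown here, the geometry of the double bond is the only thing that changes, and no step of this kind is known from the measured compounds. The size of the effect in this assay therefore rests on expectation alone. The writer expects the E-drawn compound 3 to act at smaller amounts, and the step of an 80-fold lower number from compound 1 to compound 3 (1.90 log units; beyond the scatter) is the estimated size of that change. Compound 3 is therefore estimated at 1000 nM in this assay, within a wide range from 30 nM to 30000 nM.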

Compound 3, concentration for half-maximal activity: > 100000 nM
Compound 3 gave a limit, no number (the forecaster's own chance of this, stated with the estimate: 5%); middle value at least 100-fold (2.00 log units) from the limit.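

In this assay compound 3 gives > 100000 nM, a limit of the assay and not a number: the limit of > 100000 nM in this assay, at which 1 of the 3 values shown sits. Among these compounds, the pair gives the first step in this set that changes nothing but the geometry of the double bond, and it reads an at least 1.2-fold higher number from compound 1 to compound 3 (0.09 log units; that floor lies within the scatter), so turning the double bond from Z to E brings no sign of an effect at smaller amounts, though the floor of this step lies within the scatter and does not by itself set the two compounds apart. Any difference in this pair can therefore be laid only on the double bond, and the pair gives no reason to favour the E-drawn form in this assay: the fact that compounds 1 and 3 differ only in the configuration as drawn.

On these data alone, how far compound 3 actually lies from compound 1 stays open, as the step has only a floor and no measured size. Also open, as far as these compounds go, is whether the double bond geometry would matter more with a methyl ester or a tetrazole in place of the carboxylic acid, or with an ethyl group in place of the methyl on the double bond.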